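The compounds below may be only part of what the source reports. "The series", "measured", "known", "first", "only" and "open" are said of these compounds alone.

Measured compounds, with their values in a functional assay on HepG2 cells (Homo sapiens) for antiproliferative activity, read by MTT assay, with a stated time of 24 h; a higher number here means a weaker inhibitor, a lower number a stronger inhibitor:
compound 1 `Cc1ccc(-c2nn(-c3ccccc3)cc2-c2nc3ccccc3n2S(=O)(=O)c2ccc(C)cc2)cc1`, 520 nM
compound 2 `Cc1ccc(-c2nn(-c3ccccc3)cc2-c2nc3ccccc3n2S(=O)(=O)c2ccc(F)cc2)cc1`, 5060 nM
compound 3 `Cc1ccc(-c2nn(-c3ccccc3)cc2-c2nc3ccccc3n2S(=O)(=O)c2ccc(Cl)cc2)cc1`, 5520 nM

Compound 3 gives the highest of the three values in this assay; the nearest step is a 1.1-fold higher number from compound 2 to compound 3 (0.04 log units; within the scatter), which is within the scatter, while the step of an 11-fold higher number from compound 1 to compound 3 (1.03 log units; beyond the scatter) lies beyond it. Compound 2 stands a 9.7-fold higher number from compound 1 to compound 2 (0.99 log units; beyond the scatter) from compound 1.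

Compound 4 `O=S(=O)(c1ccc(Cl)cc1)n1c(-c2cn(-c3ccccc3)nc2-c2ccc(F)cc2)nc2ccccc21` is not yet measured. The change from compound 3 to compound 4 is fluoro in place of methyl on an aromatic carbon. Among the compounds with values here, no measured step bears on it directly: the one change of fluoro in place of methyl on an aromatic carbon that is measured, a 9.7-fold higher number from compound 1 to compound 2 (0.99 log units; beyond the scatter), sits on the other aromatic ring of the molecule, the one carrying the sulfonyl, not on the 4-methylphenyl that becomes 4-fluorophenyl here. That step was a modest weakening, so the same exchange at the new place is expected to weaken at most modestly, and may well stay within the scatter. The expected step of a 1.4-fold higher number from compound 3 to compound 4 (0.16 log units; within the scatter) is therefore small and toward a higher number. Compound 4 is estimated at 8000 nM in this assay, with a range from 3000 nM to 25000 nM.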

Compound 4, half-maximal inhibitory concentration: 4230 nM
Compound 4: middle estimate off by 1.9-fold (0.28 log units), on the high side, and the stated range covers the measured number.
By their numbers in this assay, from the lowest: compound 1; then compounds 4, 2 and 3 (each within the scatter of the next).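

In this assay the exchange of 4-methylphenyl for 4-fluorophenyl gives a 1.3-fold lower number from compound 3 to compound 4 (0.12 log units; within the scatter) and so makes no readable difference at this position, at least with chloro on the sulfonyl-bearing aryl ring. The earlier compounds shown here showed this exchange only on the sulfonyl-bearing aryl ring, where it gave a 9.7-fold higher number from compound 1 to compound 2 (0.99 log units; beyond the scatter) and therefore suggested more sensitivity than appears here. The size of the methyl to fluoro exchange therefore does not carry over from one place in the series to the other: the same change on two cores in this assay, a 9.7-fold higher number (0.99 log units; beyond the scatter) from compound 1 to compound 2 and a 1.3-fold lower number (0.12 log units; within the scatter) from compound 3 to compound 4, 13-fold (1.10 log units) apart, beyond the scatter of two such steps.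

On these data alone, this position has been read only with chloro on the sulfonyl-bearing aryl ring, so it remains open whether 4-fluorophenyl would be equally tolerated with the methyl of compound 1 in that place, where the number is 520 nM in this assay. It also remains open how this position would respond to a methoxy group, an amine or a longer chain, since the compounds shown carry only methyl and fluoro here.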